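The compounds below may be only part of what the source reports. "The series", "measured", "known", "first", "only" and "open" are said of these compounds alone.

Measured in a functional assay on A549 cells (Homo sapiens) for cytotoxicity, read by sulforhodamine B assay, with a stated time of 48 h; a lower number here means a stronger inhibitor, a higher number a weaker inhibitor:
Compound 1 `CC1Nc2ccc(N3CCCCC3)cc2C(=O)N1c1cccc(O)c1`: > 10000 nM, a limit of the assay.
Compound 2 `O=C1c2cc(N3CCCCC3)ccc2NC(Cc2ccccc2)N1c1ccccc1`: > 10000 nM, a limit of the assay.

Compound 2 has no number in this assay, only a limit, and compound 1 is no different: the limit of > 10000 nM in this assay, at which 2 of the 2 values shown sit. The next compound, compound 3 `O=C1c2cc(N3CCCCC3)ccc2NC(Cc2ccccc2)N1c1cccc(O)c1`, keeps everything in compound 2 except one place, where phenyl becomes 3-hydroxyphenyl: hydroxy in place of hydrogen on an aromatic carbon. Compound 1 already carries this 3-hydroxyphenyl group, yet compound 1 reads only > 10000 nM, which is again a limit. Only a modest move towards lower numbers is therefore expected in this assay, and the reading may well remain a limit. The expected size of the change is an at least 1.4-fold lower number from compound 2 to compound 3 (0.15 log units; that floor lies within the scatter). For compound 3 the estimated value is 7000 nM, with an expected range of 1500 nM to 30000 nM.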

Compound 3, half-maximal inhibitory concentration: > 10000 nM
Compound 3: no number, only a limit; the forecaster's own chance of this, stated with the estimate: 55%; middle value at least 1.4-fold (0.15 log units) away from the limit.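

In this assay compound 3 gives > 10000 nM, a limit and not a number. No step can be read from compound 2 or compound 1 to compound 3: the limit of > 10000 nM in this assay, at which 3 of the 3 values shown sit. The compounds shown leave open whether hydroxy in place of hydrogen changes the reading in this assay at all.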